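Swapping a benzimidazole for a phenoxymethyl arm

The source may hold more compounds than are shown below. What is called first, only, known or untested is meant among the compounds shown, and "the series" means these compounds.

Measured compounds in a functional assay on CHO-K1 cells for agonist activity at somatostatin receptor type 2 (Homo sapiens), read by cAMP accumulation, with a stated time of 30 min; on this read-out lower numbers stand for an effect already at smaller amounts and higher numbers for an effect only at larger amounts of compound:
compound 1 `NC1CCN(c2c(-c3cc(F)cc(Cl)c3)cncc2-c2nc3cc(F)ccc3[nH]2)CC1`: 0.081 nM
compound 2 `Cc1cc(C)cc(-c2cncc(-c3nc4cc(C)cc(C)c4[nH]3)c2N2CCC(N)CC2)c1`: 0.013 nM
compound 3 `Cc1cc(C)cc(-c2cncc(-c3nc4cc(Cl)ccc4[nH]3)c2N2CCC(N)CC2)c1`: 0.015 nM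

Compound 3 sits second highest of the three numbers in this assay; its value and that of compound 2 lie within the usual scatter of each other, while compound 1 stands clearly higher. Compound 4 `Cc1cc(C)cc(OCc2cncc(-c3cc(C)cc(C)c3)c2N2CCC(N)CC2)c1` arises from compound 3 through one change: (3,5-dimethylphenoxy)methyl in place of 5-chloro-1H-benzimidazol-2-yl on an aromatic carbon. Among the measured compounds shown here, the hydrogen-bond donor carried by the leaving group is gone, and no measured pair shows what that costs. The expected step from compound 3 to compound 4 is a 100-fold higher number from compound 3 to compound 4 (2.00 log units; beyond the scatter), a loss of potency well beyond the scatter. The estimated value for compound 4 in this assay is 1.5 nM, within a range from 0.15 nM to 15 nM.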

Compound 4, half-maximal effective concentration: 3.7 nM
Compound 4: middle estimate off by 2.5-fold (0.39 log units), on the low side, within the range that was stated.
By their numbers in this assay, from the lowest: compounds 2 and 3 (each within the scatter of the next); then compound 1; then compound 4.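

Replacing 5-chloro-1H-benzimidazol-2-yl with (3,5-dimethylphenoxy)methyl gives, in this assay, a 250-fold higher number from compound 3 to compound 4 (2.39 log units; beyond the scatter), even though both groups have 10 heavy atoms. This position therefore responds strongly to what is placed there, which compounds 1 to 3 could not show because they all carry a benzimidazole there. Nothing here explains the loss.

The change removes the hydrogen-bond donor, the chlorine and the five-membered ring together, so this one step cannot separate them. As far as these compounds go, how an amide or a carboxylic acid would fare at this position also remains open.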